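The source may hold more compounds than are shown below. What is called first, only, known or untested is meant among the compounds shown, and "the series" means these compounds.

Among the three compounds measured in a functional assay on A549 cells (Homo sapiens) for inhibition, tested at 10 uM (on this read-out lower numbers stand for a weaker effect and higher numbers for a stronger effect at the one concentration tested), compound 3 `Cc1ccc(S(=O)(=O)n2cc(-c3cc(C(F)(F)F)ccn3)c3ccccc32)cc1` stands highest with 35%. Compound 1 `COc1ccc2c(c1)c(-c1cc(C(F)(F)F)c(C#N)c(-c3cn(S(=O)(=O)c4ccc(C)cc4)c4ccc(OC)cc34)n1)cn2S(=O)(=O)c1ccc(C)cc1` gives 25.2%, which lies within the scatter of compound 3. Going by the values given here, compound 2 `COc1ccc2c(c1)c(-c1cc(C(F)(F)F)ccn1)cn2S(=O)(=O)c1ccc(C)cc1` gives 9.9%, and the step of a number 25.1 percentage points higher from compound 2 to compound 3 (beyond the scatter) is the only single-place change measured here. Compound 4 `Cc1ccc(S(=O)(=O)n2cc(-c3cc(C(F)(F)F)ccn3)c3cc(OCc4ccccc4)ccc32)cc1` differs from compound 3 by benzyloxy in place of hydrogen on an aromatic carbon. The step from compound 2 to compound 3 bears on this change, since it also concerns an oxygen-linked group on the same fused ring, and it was modest. The entering benzyloxy likewise carries one oxygen and one hydrogen-bond acceptor. Compound 4 is therefore expected to give a lower number, by a number 13 percentage points lower from compound 3 to compound 4 (beyond the scatter), though with little certainty. Compound 4 is estimated at 22%, within a range from 5% to 40%.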

Compound 4, a percentage reported as inhibition, at one concentration (the size of the read-out at that concentration, not a potency): 9.9%
For compound 4 the middle estimate is 12.1 percentage points above the measured one; measured number inside the range.
By their numbers in this assay, from the lowest: compounds 2 and 4 (each within the scatter of the next); then compounds 1 and 3 (each within the scatter of the next).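

Going by these compounds alone, with benzyloxy on this aromatic carbon, this assay gives a number 25.1 percentage points lower from compound 3 to compound 4 (beyond the scatter), so methoxy is no longer the only oxygen-linked group here that goes with a lower number. Extending methoxy by a phenyl gives no change at the digits printed from compound 2 to compound 4 (within the scatter), so the two oxygen-linked groups cannot be told apart on this read-out. Nothing available offers an explanation for this result. The compounds shown leave open whether the oxygen link matters or any group on this carbon would do the same. An amine or a methyl at this position would bear on that question.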